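Trifluoromethyl for Methyl on a Pendant Phenyl Ring

The source may report more compounds than this note shows. Statements on the series, on what has been measured and on what is new or still open speak of the compounds shown alone.

Compound 1 `O=C(O)CCC(=O)N1N=C(c2c(-c3ccccc3)c3cc(Cl)ccc3[nH]c2=O)CC1c1ccc(F)cc1`: 14000 nM
Compound 2 `Cc1ccc(-c2c(C3=NN(C(=O)CCC(=O)O)C(c4ccc(Cl)cc4)C3)c(=O)[nH]c3ccccc23)cc1`: 1400 nM

Of the compounds shown here, two have been tested in an assay on cells (Oocyte) for negative allosteric modulation of glutamate receptor ionotropic, NMDA 2D (Rattus norvegicus), read by two-electrode voltage clamp; a higher number here means a weaker inhibitor, a lower number a stronger inhibitor. Compound 1 gives 14000 nM, while compound 2 gives 1400 nM. Within the data shown here, compound 2 thus stands at the lowest of the two numbers, and its only neighbour, compound 1, sits a full step higher, a gap beyond the usual scatter. The two compounds differ in several places at once. No single change can be read from that gap.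

Compound 3 `O=C(O)CCC(=O)N1N=C(c2c(-c3ccc(C(F)(F)F)cc3)c3ccccc3[nH]c2=O)CC1c1ccc(Cl)cc1` is compound 2 with one change: trifluoromethyl in place of methyl on an aromatic carbon. Among the measured compounds shown here, no measured pair shows this change, so its effect in this assay is unknown. A small step in either direction, or none beyond the scatter, is expected from compound 2 to compound 3 a 1.1-fold higher number from compound 2 to compound 3 (0.03 log units; within the scatter). Compound 3 is therefore estimated at 1500 nM, within a range of 500 nM to 5000 nM.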

Compound 3, half-maximal inhibitory concentration: 2800 nM
For compound 3 the middle estimate is 1.9-fold (0.27 log units) below the measured one; measured number inside the range.
By their numbers in this assay, from the lowest: compounds 2 and 3 (each within the scatter of the next); then compound 1.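

Among these compounds, replacing 4-methylphenyl with 4-(trifluoromethyl)phenyl gives a 2.0-fold higher number from compound 2 to compound 3 (0.30 log units; within the scatter) in this assay and is the first single change in this set that can be read on its own. At this position, on the pendant ring and para to a large group, one heavy atom can thus give way to four without a difference that stands out from the scatter. Nothing measured here bears on why the two groups read alike.

Still open, going by these compounds, is whether groups of a different kind would be tolerated as well at this position, such as an amine, a carboxylic acid or a longer alkyl chain. Also open, on these data alone, is whether the same swap would read alike on the core of compound 1, which differs from compound 2 in several places.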